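A few compounds are considered here, and "the series" means these few. Any claim that something is new, unique, unknown or untested is made for them only; others in the source may bear on it.

Of the compounds shown here, three built on one shared core have been measured in a functional assay on A-375 cells (Homo sapiens) for antiproliferative activity, read by CCK-8 assay, with a stated time of 72 h, tested at 8 uM; on this read-out lower numbers stand for a weaker effect and higher numbers for a stronger effect at the one concentration tested. Compound 1 `Nc1ccccc1NC(=O)c1ccc(CSC(=S)N2CCc3ccccc32)cc1` gives 85.4% in this assay. Compound 2 `CN(C(=S)SCc1ccc(C(=O)Nc2ccccc2N)cc1)c1cccnc1` gives 87.7% in this assay. Compound 3 `Nc1ccccc1NC(=O)c1ccc(CSC(=S)N2CCN(c3ccc(F)cc3)CC2)cc1` gives 76.3% in this assay.

Going by the values given here, only one pair of measured compounds differs in a single place: a number 2.3 percentage points higher from compound 1 to compound 2 (within the scatter). Exchanging the group on the thiocarbonyl carbon therefore changed the read-out by less than the usual scatter.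

Compound 3 sits at the low end of the three: its value lies within the scatter of the value of compound 1, while the value of compound 2 is beyond the scatter above it.

Compound 4 `Nc1ccccc1NC(=O)c1ccc(CSC(=S)N2CCN(c3cnccn3)CC2)cc1` has not yet been measured in this assay. It differs from compound 3 in one place: pyrazin-2-yl in place of 4-fluorophenyl on an amine nitrogen in a ring. Among the compounds with values here, this change sits on an amine nitrogen in a ring, a position no measured step has touched; the one step seen, from compound 1 to compound 2, was small and concerned the thiocarbonyl carbon, so it offers only weak guidance. The step of a number 0.3 percentage points lower from compound 3 to compound 4 (within the scatter) is estimated to stay within the scatter, with no direction favoured. Compound 4 is therefore expected to give about 76% in this assay, estimated to lie between 58% and 90%.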

Compound 4, a percentage reported as inhibition, at one concentration (the size of the read-out at that concentration, not a potency): 85.8%
The estimate for compound 4 lay 9.8 percentage points below the measured number; the range from low to high includes it.
By their numbers in this assay, from the lowest: compounds 3, 1, 4 and 2 (each within the scatter of the next, the first and the last beyond it).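

At the amine nitrogen in the six-membered ring, the first step measured at this position reads, in this assay, a number 9.5 percentage points higher from compound 3 to compound 4 (within the scatter). The aromatic ring on this nitrogen can thus go from one of carbon only, carrying a fluorine, to pyrazin-2-yl, with 2 hetero atoms and 2 hydrogen-bond acceptors, while the two read-outs remain within the usual scatter of each other. This single pair gives no sign that the read-out at this concentration depends on which of these two aromatic rings is present, though it cannot exclude a smaller real difference hidden by the scatter, and no measured property of either group is available to account for the step.

The compounds shown leave open whether this nitrogen tolerates a group with no aromatic ring at all, such as a methyl or a short chain ending in a carboxylic acid, or an aromatic ring carrying an amine. With only one concentration tested, they also leave open whether compound 3 and compound 4 differ in potency.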